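The source may report more compounds than this note shows. Statements on the series, on what has been measured and on what is new or still open speak of the compounds shown alone.

Among the measured compounds shown here, compound 3 `Cc1cc(C)nc(Oc2ccc(NC(=O)Nc3ccc(F)cc3)cc2)n1` is the one member of this small set that gives an actual number in a functional assay on KB cells (Homo sapiens) for cytotoxicity, read by MTT assay, with a stated time of 3 days (on this read-out higher numbers stand for weaker inhibition and lower numbers for stronger inhibition), where compound 3 reaches 48400 nM. Compound 1 `Cc1cc(C)nc(Oc2ccc(NC(=O)Nc3ccccc3)cc2)n1` gives only a limit, > 50000 nM, in this assay. Compound 2 `Cc1cccc(NC(=O)Nc2ccc(Oc3nc(C)cc(C)n3)cc2)c1` likewise gives only a limit, > 50000 nM, in this assay. Because of the limit of > 50000 nM in this assay, at which 2 of the 3 values shown sit, the step that the two limits leave unreadable from compound 1 to compound 2 cannot be read. The step from hydrogen to fluoro on an aromatic carbon, an at least 1.0-fold lower number from compound 1 to compound 3 (0.01 log units; that floor lies within the scatter), and the step from 3-methylphenyl to 4-fluorophenyl, an at least 1.0-fold lower number from compound 2 to compound 3 (0.01 log units; that floor lies within the scatter), both sit at a floor that lies within the scatter, so compound 3 stands at the weak end of what this assay can resolve.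

Compound 4 `Cc1cc(C)nc(Oc2ccc(NC(=O)Nc3ccc(Cl)cc3)cc2)n1` differs from compound 3 by chloro in place of fluoro on an aromatic carbon. For the measured compounds named here, the only measured step that touches this position, from hydrogen to fluoro in an at least 1.0-fold lower number from compound 1 to compound 3 (0.01 log units; that floor lies within the scatter), was too small to stand out from the scatter, so there is no basis here to expect a step beyond the scatter from compound 3 to compound 4 in this assay in either direction. The step expected for compound 4 is therefore a 1.2-fold lower number from compound 3 to compound 4 (0.08 log units; within the scatter). Compound 4 is thus estimated at 40000 nM, within a range of 15000 nM to 100000 nM in this assay, with a real chance that only a limit is reported.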

Compound 4, half-maximal inhibitory concentration: 25400 nM
Estimate against measurement, compound 4: 1.6-fold (0.20 log units) above, and the stated range covers the measured number.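

At this place, on an aromatic carbon para to a large group, chloro in place of fluoro gives a 1.9-fold lower number from compound 3 to compound 4 (0.28 log units; within the scatter) in this assay, so this read-out does not separate the two groups. Compound 4 joins compound 3 in giving an actual number rather than a limit, which gives this position its first readable step between two substituents. Set against compounds 1 and 2, an at least 1.9-fold lower number from compound 1 to compound 4 (0.29 log units; that floor lies within the scatter) and an at least 1.9-fold lower number from compound 2 to compound 4 (0.29 log units; that floor lies within the scatter) remain floors rather than sizes because of the limit in this assay: the limit of > 50000 nM in this assay, at which 2 of the 4 values shown sit.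

The compounds shown leave open whether another group at this place, such as bromo, trifluoromethyl, methoxy or an amine, would move the number beyond the scatter. They also leave open how far unsubstituted phenyl really lies from the 4-fluorophenyl and 4-chlorophenyl compounds, and whether the 3-methylphenyl compound differs from them by more than the scatter, as compounds 1 and 2 give only limits.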